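A few compounds are considered here, and "the series" means these few. Any claim that something is new, unique, unknown or untested is made for them only; others in the source may bear on it.

Compound 1 `O=c1ccoc2cc(OCc3cn(Cc4ccccc4)nn3)ccc12`: > 100000 nM (a limit)
Compound 2 `Cc1ccccc1Cn1cc(COc2ccc3c(=O)ccoc3c2)nn1`: > 100000 nM (a limit)
Compound 3 `O=c1ccoc2cc(OCc3cn(Cc4cccc(Cl)c4)nn3)ccc12`: 13700 nM

All three were read in a functional assay on A549 cells (Homo sapiens) for cytotoxicity, read by MTT assay, with a stated time of 48 h; on this read-out lower numbers stand for stronger inhibition and higher numbers for weaker inhibition. Compound 3 alone has a number here; the others stand at the limit of > 100000 nM in this assay, at which 2 of the 3 values shown sit.

Compound 4 `O=c1ccoc2cc(OCc3cn(Cc4ccc(Br)cc4)nn3)ccc12` differs from compound 3 by one change: 4-bromophenyl in place of 3-chlorophenyl on a saturated chain carbon bound to an aromatic nitrogen. The nearest measured evidence is the chloro step, an at least 7.2-fold lower number from compound 1 to compound 3 (0.86 log units; beyond the scatter), which is at least modest. The methyl step, a step that the two limits leave unreadable from compound 1 to compound 2, gives no size. Among the measured compounds shown here, no measured step covers bromo or the 4-bromophenyl placement, so the direction is uncertain. With a halogen retained, only a small change is expected: a 1.3-fold higher number from compound 3 to compound 4 (0.12 log units; within the scatter). For compound 4 the estimated value is 18000 nM, with an expected range of 6000 nM to 70000 nM.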

Compound 4, half-maximal inhibitory concentration: > 100000 nM
Compound 4 ended at the assay's limit (the forecaster's own chance of this, stated with the estimate: 30%); middle value at least 5.5-fold (0.74 log units) from the limit.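

Replacing 3-chlorophenyl with 4-bromophenyl on the saturated chain carbon bound to an aromatic nitrogen gives an at least 7.2-fold higher number from compound 3 to compound 4 (0.86 log units; beyond the scatter) in this assay, so a halogen on this aromatic ring does not by itself secure a readable value. The steps from compound 1 and from compound 2 to compound 4 cannot be read. Compound 3 remains the only compound with a number, and compound 4 joins the others at a limit: the limit of > 100000 nM in this assay, at which 3 of the 4 values shown sit.

Both the halogen and its place change in this step, and the compounds shown do not separate the two. From the compounds shown here alone, whether an amine or a carboxylic acid on this ring would give a readable value also remains open.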